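A Second Aryl Swap on the Aromatic Nitrogen

The source may hold more compounds than are shown below. What is called first, only, known or untested is meant among the compounds shown, and "the series" means these compounds.

Compound 3 `N#CC1=C(N)Oc2c(N)cc3nc4ccccc4nc3c2C12C(=O)N(Cc1cnnn1-c1ccc(F)cc1)c1ccccc12` stands at the edge of what a functional assay on A549 cells (Homo sapiens) for antiproliferative activity, read by MTT assay, with a stated time of 48 h (a higher number here means a weaker inhibitor, a lower number a stronger inhibitor), reports: in this assay compound 3 gives > 50000 nM, which is a limit and not a number. Compound 1 `N#CC1=C(N)Oc2c(c3nc4ccccc4nc3c3ccccc23)C12C(=O)N(Cc1cnnn1-c1cccc(S(N)(=O)=O)c1)c1ccccc12` shares the core, and in this assay compound 1 gives 44200 nM. Compound 2 `Cc1ccc(C)c(-n2nncc2CN2C(=O)C3(C(C#N)=C(N)Oc4c3c3nc5ccccc5nc3c3ccccc43)c3ccccc32)c1` in this assay gives > 50000 nM, again a limit. The change from compound 3 to compound 4 `Cc1ccc(C)c(-n2nncc2CN2C(=O)C3(C(C#N)=C(N)Oc4c(N)cc5nc6ccccc6nc5c43)c3ccccc32)c1` is 2,5-dimethylphenyl in place of 4-fluorophenyl on an aromatic nitrogen. Going by the values given here, the one measured step with the same entering group, an at least 1.1-fold higher number from compound 1 to compound 2 (0.05 log units; that floor lies within the scatter), ended at the limit of > 50000 nM in this assay, at which 2 of the 3 values shown sit, and so fixes only a floor. In this assay compound 4 is therefore expected to give 60000 nM, within 30000 nM to 200000 nM, most likely reported as a limit only. The expected step that the limit leaves unreadable from compound 3 to compound 4 lies within the scatter.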

Compound 4, half-maximal inhibitory concentration: > 50000 nM
Compound 4: a limit, no number; the forecaster's own chance of this, stated with the estimate: 85%; the middle value does not contradict the limit.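

In this assay, going by these compounds alone, compound 3 and compound 4 both stand at a limit, so no step between them can be read: the limit of > 50000 nM in this assay, at which 3 of the 4 values shown sit. The compounds shown leave open whether 2,5-dimethylphenyl and 4-fluorophenyl differ at all on this shared core.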